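A few compounds are considered here, and "the series" means these few. Any claim that something is new, unique, unknown or untested is made for them only; others in the source may bear on it.

Cytotoxicity here is followed in an ADME assay on HepG2 cells (Homo sapiens) for cytotoxicity, read by luminescence, CellTiter-Glo and ATP content, with a stated time of 72 h (on this read-out higher numbers stand for an effect only at larger amounts of compound and lower numbers for an effect already at smaller amounts), where the aim is usually a high number, meaning the cells are harmed only by large amounts of compound. Of the compounds shown here, two have been measured. Compound 1 `COc1ccc(F)cc1CNCCCNc1ccnc2cc(Cc3ccc(C#N)cc3)ccc12` carries a 5-fluoro-2-methoxybenzyl group on the amine at the end of its chain, and in this assay compound 1 gives 6050 nM. Compound 2 `COc1ccc(-c2ccc3c(NCCCNCc4ccco4)ccnc3c2)cc1` shares the chain and the amine but ends in a (furan-2-yl)methyl group, and in this assay compound 2 gives 6000 nM. These two numbers lie within the usual scatter of each other, so neither compound can be said to stand apart from the other.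

Compound 3 `COc1ccc(-c2ccc3c(NCCCNCc4cc(F)ccc4OC)ccnc3c2)cc1` has not yet been measured. It differs from compound 2 in one place: 5-fluoro-2-methoxyphenyl in place of furan-2-yl on a saturated chain carbon bound to an amine nitrogen. The group that enters is the same one that compound 1 already carries, and compound 1 with 6050 nM sits within the scatter of compound 2. On that basis no step beyond the scatter is expected in this assay. The expected step from compound 2 to compound 3 is no change at the digits printed from compound 2 to compound 3 (within the scatter). Compound 3 is therefore estimated at 6000 nM, with a range from 2500 nM to 14000 nM.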

Compound 3, half-maximal effective concentration: 5960 nM
Compound 3: the middle estimate sits 1.0-fold (0.00 log units) above what was measured, within the range that was stated.
By their numbers in this assay, from the lowest: compounds 3, 2 and 1 (each within the scatter of the next).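

In this assay, 5-fluoro-2-methoxyphenyl in place of furan-2-yl on a saturated chain carbon bound to an amine nitrogen gives a 1.0-fold lower number from compound 2 to compound 3 (0.00 log units; within the scatter), so at this place a six-membered aromatic ring of carbon only, with its fluorine and methoxy group, cannot be told apart from the five-membered furan ring on this read-out. The compounds also now allow a second comparison at a different place: 4-methoxyphenyl in place of 4-cyanobenzyl on an aromatic carbon gives a 1.0-fold lower number from compound 1 to compound 3 (0.01 log units; within the scatter), so this exchange on the shared core also shows no step beyond the scatter. No measurement at hand bears on why these numbers lie so close together.

From the compounds shown here alone, all three compounds carry an aromatic ring on the saturated chain carbon bound to the amine nitrogen, so it remains open whether a carboxylic acid or a simple alkyl chain at that place would also stay within the scatter. A longer chain between the core and the amine is likewise untested among the compounds shown, so its effect on the cells remains unknown.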